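A few compounds are considered here, and "the series" means these few. Any claim that something is new, unique, unknown or untested is made for them only; others in the source may bear on it.

Among the compounds with values here, in a functional assay on HL-60 cells (Homo sapiens) for inhibition, read by CCK-8 assay, with a stated time of 48 h, tested at 20 uM (on this read-out higher numbers stand for more inhibition of growth at the one concentration tested and lower numbers for less inhibition of growth), only two related compounds have been tested so far. Compound 1 (`N#C/C(=C\c1ccccc1OS(=O)(=O)c1ccc(F)cc1)C(=O)Nc1nnc(Cc2ccc(F)cc2)s1`) gives 13% and compound 2 (`COc1ccc(S(=O)(=O)Oc2ccccc2/C=C(\C#N)C(=O)Nc2nnc(Cc3cccc(F)c3)s2)cc1`) gives 100% on this measure. Compound 2 is the higher of the two, and the gap lies well beyond the scatter. However, these compounds differ in more than one place, so the gap cannot be credited to any single structural change.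

Compound 3 (`N#C/C(=C\c1ccccc1OS(=O)(=O)c1ccc(F)cc1)C(=O)Nc1nnc(Cc2cccc(F)c2)s1`) has not yet been measured. It is compound 2 with one change (fluoro in place of methoxy on an aromatic carbon): fluoro in place of methoxy on an aromatic carbon, para to a large group, which turns (4-methoxyphenyl)sulfonyl into (4-fluorophenyl)sulfonyl.

Within the data shown here, the only guide is indirect. Among the measured compounds shown here, compound 1 also carries (4-fluorophenyl)sulfonyl and reaches just 13% of inhibition, so some loss seems likely, although no measured pair isolates this change. The expected step of a number 40 percentage points lower from compound 2 to compound 3 (beyond the scatter) is a fall beyond the scatter, and its size is quite uncertain. For compound 3 the estimated inhibition is 60% within a range from 20% to 100% in this single-concentration test.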

Compound 3, percent growth inhibition at one concentration: 22%
Compound 3: middle estimate off by 38 percentage points, on the high side; the range from low to high includes it.
By their numbers in this assay, from the lowest: compounds 1 and 3 (each within the scatter of the next); then compound 2.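

In this assay, compound 2 and compound 3 differ only in the group on the sulfonyl side, where (4-methoxyphenyl)sulfonyl becomes (4-fluorophenyl)sulfonyl, and this single change gives a number 78 percentage points lower from compound 2 to compound 3 (beyond the scatter). Within the data shown here, this is the first direct reading of the change, and it shows that growth inhibition in this pair depends strongly on what sits at this one position, which the first two compounds, differing in more than one place, could not show. Compound 1 and compound 3 share (4-fluorophenyl)sulfonyl, and placing 3-fluorophenyl where 4-fluorophenyl stood on the chain carbon gives a number 9 percentage points higher from compound 1 to compound 3 (within the scatter), so with this sulfonyl group the fluorine's place on that other ring makes no clear difference, and nothing shown here explains either step.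

Going by these compounds, it remains open whether other groups at this position, such as a hydrogen, a chloro, a methyl, an ethoxy or an amine, would keep the inhibition seen with methoxy or lose it as fluoro does. Also open, on these data alone, is whether methoxy has the same large effect when 4-fluorophenyl stands on the chain carbon, since only 3-fluorophenyl shows this step.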